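A few compounds are considered here, and "the series" means these few. Any claim that something is new, unique, unknown or untested is made for them only; others in the source may bear on it.

Of the compounds shown here, three from this series have been tested in a functional assay on the whole organism (strain NMRI) with Mus musculus as the target, with a stated time of 0.5 h; a lower number here means that less compound is needed, a higher number that more compound is needed for the effect. Compound 1 `O=[N+]([O-])c1ccc(Cn2cc(CO/N=C/c3c(-c4ccc(F)cc4)nc4ccc(Br)cn34)nn2)cc1` gives 40 mg/kg. Compound 2 `Cc1ccc(-c2nc3ccc(Br)cn3c2/C=N/OCc2cn(Cc3ccc(C#N)cc3)nn2)cc1` gives 40 mg/kg, and compound 3 `COc1ccc(Cn2cc(CO/N=C/c3c(-c4ccc(C)cc4)nc4c(C)cccn34)nn2)cc1` gives 40 mg/kg. Compound 2 is thus level with compounds 1 and 3 at the digits shown; its nearest neighbour is compound 1 and its furthest is compound 3, and neither gap goes beyond the scatter. Compound 4 `Cc1ccc(Cn2cc(CO/N=C/c3c(-c4ccc(C)cc4)nc4ccc(Br)cn34)nn2)cc1` has not yet been tested in this assay. It differs from compound 2 in one place (methyl in place of cyano on an aromatic carbon). Within the data shown here, no measured step exists between compounds that differ at this position, and all three known values lie level, so no step beyond the scatter is expected in either direction. Compound 4 is therefore estimated at 40 mg/kg, within 20 mg/kg to 80 mg/kg, an expected step of no change at the digits printed from compound 2 to compound 4 (within the scatter) that should stay inside the scatter.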

Compound 4, minimum effective dose: 40 mg/kg
Beside the measured number, compound 4's estimate shows no gap at the digits printed; the range from low to high includes it.
By their numbers in this assay, from the lowest: compounds 1, 2, 3 and 4 (each within the scatter of the next).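

In this assay the first pair differing in one place shows no change at the digits printed from compound 2 to compound 4 (within the scatter) for methyl in place of cyano. At this position, on an aromatic carbon para to a large group, the swap removes a triple bond and a hydrogen-bond acceptor, yet the read-out stays level. No supporting data bear on this result. As far as these compounds go, whether an amine, a carboxylic acid or a longer chain at this position would also stay level remains open. So does the effect of changes elsewhere on the shared core.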